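A Bromine Substitution Tried on a Second Ring

The source may hold more compounds than are shown below. What is called first, only, known or untested is meant among the compounds shown, and "the series" means these compounds.

Compound 1 `O=C(CCc1ccccc1)Nc1nc2ccccc2c(=O)s1` and compound 2 `O=C(CCCc1ccccc1)Nc1nc2ccccc2c(=O)s1` share one core and differ only in the side chain: benzyl in place of phenyl on a saturated chain carbon, two bonds along the chain from a carbonyl carbon. In an in vitro assay on cells for inhibition of Amine oxidase [flavin-containing] B (Homo sapiens), read by fluorescence and Amplex Red, with stated times of 30 min and 45 min (a higher number here means a weaker inhibitor, a lower number a stronger inhibitor), compound 1 gives 17.6 nM and compound 2 gives 34.9 nM, a step of a 2.0-fold higher number from compound 1 to compound 2 (0.30 log units; within the scatter). Compound 3 `O=C(CCc1ccccc1Br)Nc1nc2ccccc2c(=O)s1` carries bromo in place of hydrogen on an aromatic carbon, and in this assay compound 3 gives 2.09 nM, so the step is an 8.4-fold lower number from compound 1 to compound 3 (0.93 log units; beyond the scatter). Compound 4 `O=C(CCCc1ccccc1)Nc1nc2ccc(Br)cc2c(=O)s1` carries bromo in place of hydrogen on an aromatic carbon. This is the same kind of change, occurring twice among these compounds, yet not the same: in compound 3 the bromine sits ortho to a large group on a six-membered ring of carbon only, whereas in compound 4 it sits on a ring that is part of a fused or bridged system of two rings, meta to a fused ring and para to a fused ring. Compound 4 is expected to gain less, a 2.3-fold lower number from compound 2 to compound 4 (0.37 log units; beyond the scatter), because an 8.4-fold lower number from compound 1 to compound 3 (0.93 log units; beyond the scatter) was obtained at a different place. Compound 4 is accordingly estimated at 15 nM.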

Compound 4, half-maximal inhibitory concentration: > 10000 nM
Compound 4 gave a limit, no number; the forecaster's own chance of this, stated with the estimate: 2%; middle value at least 660-fold (2.82 log units) from the limit.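

Compound 4 reads > 10000 nM in this assay, which is a limit of the assay and not a number. Bromo in place of hydrogen on this aromatic carbon of the core gives an at least 280-fold higher number from compound 2 to compound 4 (2.45 log units; beyond the scatter), so the gain seen on the side-chain ring did not carry over: the same change on two cores in this assay, an 8.4-fold lower number (0.93 log units; beyond the scatter) from compound 1 to compound 3 and an at least 280-fold higher number (2.45 log units; beyond the scatter) from compound 2 to compound 4, at least 2400-fold (3.38 log units) apart, beyond the scatter of two such steps The two steps differ both in where the bromine sits and in the side chain, so this does not show which of the two decides the result, and the true size of the loss stays unknown.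

Open, as far as these compounds go, is how bromo at this place on the core behaves with the side chain of compound 1, and how bromo on the phenyl ring behaves with the side chain of compound 2. Also open, from the compounds shown here alone, is whether a chloro or a methoxy group at this place on the core would behave as bromo does.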